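Aryl swap on the piperidine benzyl of compound 3

This account rests on a few compounds, and the source may have more. Where it says the series, first, only, none or still open, it means among the compounds named here.

The series shares one amide core and differs in the amine attached to the aromatic ring. Compound 1 `CCCN(CCC)c1nc(C(F)(F)F)ccc1CNC(=O)C(C)c1ccc(NS(C)(=O)=O)c(F)c1` gives 0.2 nM in a functional assay on CHO-K1 cells for antagonist activity at transient receptor potential cation channel subfamily V member 1 (Homo sapiens), read by FLIPR (a higher number here means a weaker inhibitor, a lower number a stronger inhibitor), compound 2 `CC(C(=O)NCc1ccc(C(F)(F)F)nc1N1CCCC1)c1ccc(NS(C)(=O)=O)c(F)c1` gives 0.6 nM, and compound 3 `Cc1ccc(CC2CCN(c3nc(C(F)(F)F)ccc3CNC(=O)C(C)c3ccc(NS(C)(=O)=O)c(F)c3)CC2)cc1` gives 0.2 nM. Within the data shown here, compound 3 stands level with compound 1 at the digits printed, the two together the lowest of the three numbers, while compound 2 sits further off; the only single-point step, a 3.0-fold higher number from compound 1 to compound 2 (0.48 log units; beyond the scatter), concerns the amine itself.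

Compound 4 `CC(C(=O)NCc1ccc(C(F)(F)F)nc1N1CCC(Cc2ccc(F)c(F)c2)CC1)c1ccc(NS(C)(=O)=O)c(F)c1` differs from compound 3 by 3,4-difluorophenyl in place of 4-methylphenyl on a saturated chain carbon bound to a saturated ring carbon. Among the measured compounds shown here, no measured step touches this position, so nothing among the three compounds bears directly on it. The amine changes that were measured moved this assay by little, and compound 3 and compound 1 are not separated. He therefore expects compound 4 to keep a number close to that of compound 3, with a step of a 1.3-fold higher number from compound 3 to compound 4 (0.10 log units; within the scatter) in this assay, estimated at 0.25 nM and within 0.08 nM to 0.8 nM.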

Compound 4, inhibition constant: 0.2 nM
The estimate for compound 4 lay 1.3-fold (0.10 log units) above the measured number; low and high end bracket the measured number.
By their numbers in this assay, from the lowest: compounds 1, 3 and 4 (each within the scatter of the next); then compound 2.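

In this assay, the change to 3,4-difluorophenyl in place of 4-methylphenyl gives no change at the digits printed from compound 3 to compound 4 (within the scatter), the first reading at this position among the compounds shown. Among these compounds, the aryl group on the saturated chain carbon can therefore exchange its methyl substituent for two ring fluorines with no shift beyond the scatter, so 4-methylbenzyl is not the only group here that keeps the number this low. Nothing measured here accounts for this outcome.

Going by these compounds, whether the position would accept a ring carrying a carboxylic acid or an amine, or a cyclohexyl group in place of the aryl ring, remains open. This single step also cannot show whether a longer chain between the aryl ring and the saturated ring carbon would keep the number at this level.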